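Exchanging the Aryl Group on the Sulfonyl Sulfur

The compounds below may be only part of what the source reports. "The series", "measured", "known", "first", "only" and "open" are said of these compounds alone.

Compound 1 `CC(C)c1cc(C(C)C)c(S(=O)(=O)n2c(C3(O)C=CC(=O)C=C3)cc3ccccc32)c(C(C)C)c1`: 11200 nM
Compound 2 `O=C1C=CC(O)(c2cc3ccccc3n2S(=O)(=O)c2ccc3ccccc3c2)C=C1`: 5620 nM

Both were tested in a functional assay on cells (Panel NCI-60 (60 carcinoma cell lines), Homo sapiens); on this read-out lower numbers stand for higher toxicity in this test and higher numbers for lower toxicity in this test. Compound 2 has the lower of the two numbers, yet its gap to compound 1 lies within the usual scatter, so the two cannot be told apart. Compound 3 `Cc1ccc(S(=O)(=O)n2c(C3(O)C=CC(=O)C=C3)cc3ccccc32)cc1` differs from compound 2 in one place: 4-methylphenyl in place of naphthalen-2-yl on a sulfonyl sulfur. Among the compounds with values here, no measured pair shows the effect of such a change, so the step of a 1.4-fold higher number from compound 2 to compound 3 (0.15 log units; within the scatter) is expected to be modest, toward a higher number, or none beyond the scatter. Compound 3 is accordingly estimated at 8000 nM, within 3000 nM to 25000 nM.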

Compound 3, concentration lethal to 50% of the cells: 7240 nM
Compound 3: middle estimate off by 1.1-fold (0.04 log units), on the high side; measured number inside the range.
By their numbers in this assay, from the lowest: compounds 2, 3 and 1 (each within the scatter of the next).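

In this assay the exchange of naphthalen-2-yl for 4-methylphenyl on a sulfonyl sulfur gives a 1.3-fold higher number from compound 2 to compound 3 (0.11 log units; within the scatter). Within the data shown here, this is the first single-place step at this position, and it shows that one six-membered aromatic ring of carbon only and two such rings cannot be told apart in this read-out. Nothing available bears on the cause of this result. From the compounds shown here alone, it remains open whether a phenyl ring carrying an amine or a carboxylic acid would move the number beyond the scatter. The same holds for a plain alkyl chain on the sulfonyl sulfur.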